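Swapping a propyl chain for phenyl on a thiophene-bearing amine

The source may hold more compounds than are shown below. What is called first, only, known or untested is meant among the compounds shown, and "the series" means these compounds.

Measured so far:
compound 1 `C[C@H]1[C@H](NCc2sccc2C2CCCCC2)C[C@H]2C[C@@H]1C2(C)C`: 1560 nM
compound 2 `C=C(C)c1csc(CN[C@@H]2C[C@H]3C[C@@H]([C@H]2C)C3(C)C)c1`: 25000 nM
compound 3 `CCCc1csc(CN[C@@H]2C[C@H]3C[C@@H]([C@H]2C)C3(C)C)c1`: 12500 nM

In an ADME assay on MDCK cells (Canis lupus familiaris) for cytotoxicity, read by microscopy, with a stated time of 48 h (a lower number here means that less compound is tolerated, a higher number that more compound is tolerated), compound 3 gives the second highest of the three numbers. Its closest neighbour is compound 2, while compound 1, which carries a cyclohexyl on its thiophene, gives the lowest number of the set. For the measured compounds named here, the only one-point step available, a 2.0-fold lower number from compound 2 to compound 3 (0.30 log units; within the scatter), stays within the scatter.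

Compound 4 `C[C@H]1[C@H](NCc2cc(-c3ccccc3)cs2)C[C@H]2C[C@@H]1C2(C)C` is the next compound: phenyl in place of propyl on an aromatic carbon. Going by the values given here, no measured step covers this exact exchange; the lone step, from a branched alkenyl to a chain, is flat, but compound 1 shows that a six-membered ring on the thiophene went with a lower number. A modest downward move is therefore expected, a 2.5-fold lower number from compound 3 to compound 4 (0.40 log units; beyond the scatter), with compound 4 estimated at 5000 nM (range 1500 nM to 15000 nM).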

Compound 4, minimum cytotoxic concentration: 5000 nM
Compound 4: the middle estimate sits on the measured number at the digits printed; measured number inside the range.
By their numbers in this assay, from the lowest: compound 1; then compound 4; then compounds 3 and 2 (each within the scatter of the next).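

On an aromatic carbon two ring bonds from the ring sulfur, phenyl gives a step beyond the scatter in this assay: a 2.5-fold lower number from compound 3 to compound 4 (0.40 log units; beyond the scatter) and a 5.0-fold lower number from compound 2 to compound 4 (0.70 log units; beyond the scatter). For the compounds shown here, the earlier step at this position stayed within the scatter, so this is the first sign that the group placed here can change the number. Nothing measured here explains this change. From the compounds shown here alone, whether the shift belongs to phenyl alone or to other rings at this carbon stays open, and a pyridine ring or a longer chain there would bear on that.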